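The compounds below may be only part of what the source reports. "The series", "measured", "known", "first", "only" and "open" are said of these compounds alone.

Measured so far:
compound 1 `Nc1ccc2cccc(OCC3CCCC3)c2n1` — 53 nM
compound 2 `CCCOc1cccc2ccc(N)nc12` — 1100 nM

In an assay on cells with melanin-concentrating hormone receptor 1 (Homo sapiens) as the target, read by radioligand binding (on this read-out lower numbers stand for stronger inhibition and higher numbers for weaker inhibition), compound 2 gives 1100 nM, the higher of the two numbers measured in this assay; its nearest neighbour is compound 1, which in this assay gives 53 nM. Going by the values given here, the one step measured is a 21-fold higher number from compound 1 to compound 2 (1.32 log units; beyond the scatter), a large move towards weaker inhibition when the ring is removed from the chain carbon bound to the oxygen.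

Compound 3 `Nc1ccc2cccc(OC3CCCC3)c2n1` is the next member. It differs from compound 2 by cyclopentyl in place of propyl on an oxygen on an aromatic ring. Among the compounds with values here, the only measured step that bears on this change is a 21-fold higher number from compound 1 to compound 2 (1.32 log units; beyond the scatter); it runs the opposite way, from a cyclopentyl-bearing ether to a small open chain, and was large. Compound 3 brings a cyclopentyl back, though here the ring sits directly on the oxygen rather than on a chain carbon, so a step of similar size in the reverse direction is expected, with some allowance for the different attachment. Compound 3 is therefore expected to give 90 nM in this assay, within 25 nM to 350 nM, which means an expected step of a 12-fold lower number from compound 2 to compound 3 (1.09 log units; beyond the scatter).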

Compound 3, half-maximal inhibitory concentration: > 2000 nM
Compound 3: no number, only a limit; the forecaster's own chance of this, stated with the estimate: 2%; middle value at least 22-fold (1.34 log units) away from the limit.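

In this assay the reading for compound 3 is a limit of the assay and not a number: the limit of > 2000 nM in this assay, at which 1 of the 3 values shown sits. Cyclopentyl in place of cyclopentylmethyl on the oxygen gives an at least 37-fold higher number from compound 1 to compound 3 (1.57 log units; beyond the scatter), so a cyclopentyl ring on the ether is not enough on its own to hold the strength seen with compound 1, and how the ring is attached to the oxygen matters as much as its presence. Cyclopentyl in place of propyl gives an at least 1.8-fold higher number from compound 2 to compound 3 (0.25 log units; that floor lies within the scatter); that floor lies within the scatter, so compound 2 and compound 3 cannot be put in order, and the ring set directly on the oxygen shows no recovery of the loss in a 21-fold higher number from compound 1 to compound 2 (1.32 log units; beyond the scatter).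

The compounds shown leave open whether the strength of compound 1 is particular to cyclopentylmethyl or would persist with a longer chain carrying the ring, such as cyclopentylethyl, or with a different ring on the same linking carbon, such as cyclohexylmethyl or benzyl. As far as these compounds go, how far compound 3 lies beyond its limit also remains open, as does the response of this ether position to an amine on the chain.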